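Amide tail swap: methoxyphenyl for fluoropyridyl

The source may report more compounds than this note shows. Statements on the series, on what has been measured and on what is new or still open speak of the compounds shown alone.

Compound 1 `O=C(CCCCCN1CCN(c2ncccc2-c2ccncc2)CC1)NCc1ccc(F)nc1` gives 71 nM in an assay on HEK293 cells for displacement of a labelled ligand from 5-hydroxytryptamine receptor 7 (Homo sapiens), with a stated time of 60 min; on this read-out higher numbers stand for weaker inhibition and lower numbers for stronger inhibition. Compound 2 `O=C(CCCCCN1CCN(c2cccnc2-c2ccncc2)CC1)NCc1ccc(F)nc1` gives 66.7 nM in this assay, so compound 1 stands alongside compound 2 with no difference beyond the scatter. Compound 3 `COc1ccc(CNC(=O)CCCCCN2CCN(c3ncccc3-c3ccncc3)CC2)cc1` carries 4-methoxyphenyl in place of 6-fluoropyridin-3-yl on a saturated chain carbon bound to an amide-type nitrogen. Among the compounds with values here, no measured pair shows this change, and the two measured compounds differ only in the core, so the size of the step is open. The expected step of a 1.1-fold higher number from compound 1 to compound 3 (0.05 log units; within the scatter) is a shift of no more than the usual scatter in either direction. Compound 3 is expected to give 80 nM in this assay, within 30 nM to 210 nM.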

Compound 3, inhibition constant: 26.1 nM
Estimate against measurement, compound 3: 3.1-fold (0.49 log units) above, and the stated range ends above it.
By their numbers in this assay, from the lowest: compound 3; then compounds 2 and 1 (each within the scatter of the next).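

The amide tail does bear on the number in this assay: 4-methoxyphenyl in place of 6-fluoropyridin-3-yl on a saturated chain carbon bound to an amide-type nitrogen gives a 2.7-fold lower number from compound 1 to compound 3 (0.43 log units; beyond the scatter). The two earlier compounds differ only in the core and sit within the scatter of each other, so this is the only step shown that lies beyond it. Nothing on hand accounts for the change. Open, as far as these compounds go, is whether the step carries over to the core of compound 2, and whether an unsubstituted phenyl or a 4-chlorophenyl at this place matches 4-methoxyphenyl.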